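Acyl-to-sulfonyl swap on the shared core: expected activity

A few compounds are considered here, and "the series" means these few. Any claim that something is new, unique, unknown or untested is made for them only; others in the source may bear on it.

Measured compounds:
compound 1 `CCC(=O)N(C)c1ccc2[nH]c(-c3n[nH]c4ccccc34)cc2n1` — 10800 nM
compound 2 `COc1cccc(C(=O)N(C)c2ccc3[nH]c(-c4n[nH]c5ccccc45)cc3n2)c1` — 14200 nM
compound 3 `CN(C(=O)c1ccco1)c1ccc2[nH]c(-c3n[nH]c4ccccc34)cc2n1` — 30000 nM

All three were read in a functional assay on HCT-116 cells (Homo sapiens) for antiproliferative activity, read by MTT assay, with a stated time of 72 h; on this read-out lower numbers stand for stronger inhibition and higher numbers for weaker inhibition. Compound 3 gives the highest number of the three: the step of a 2.8-fold higher number from compound 1 to compound 3 (0.44 log units; beyond the scatter) and the step of a 2.1-fold higher number from compound 2 to compound 3 (0.32 log units; beyond the scatter) both lie beyond the scatter, while the step of a 1.3-fold higher number from compound 1 to compound 2 (0.12 log units; within the scatter) does not. Compound 3 is thus the weakest of this set, with compound 1 and compound 2 indistinguishable from each other.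

Compound 4 `CN(c1ccc2[nH]c(-c3n[nH]c4ccccc34)cc2n1)S(=O)(=O)c1ccc(Cl)cc1` arises from compound 3 by the change ((4-chlorophenyl)sulfonyl in place of (furan-2-yl)carbonyl on a nitrogen on an aromatic ring). Among the compounds with values here, no measured step touches a sulfonyl: the three steps so far only exchange the group on a carbonyl carbon, and the one that bears most on this change is the step from compound 2 to compound 3, a six-membered carbon ring giving way to a five-membered heteroaromatic ring, which was modest. Returning to a six-membered carbon ring might be expected to pull the number back toward that of compound 2, but the sulfonyl linker is untested, so the step of a 2.0-fold lower number from compound 3 to compound 4 (0.30 log units; within the scatter) is expected to be modest in either direction, with wide uncertainty. Compound 4 is estimated at 15000 nM, within 4000 nM to 50000 nM.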

Compound 4, half-maximal inhibitory concentration: 5980 nM
Estimate against measurement, compound 4: 2.5-fold (0.40 log units) above; the measured number falls inside the stated range.
By their numbers in this assay, from the lowest: compounds 4, 1 and 2 (each within the scatter of the next, the first and the last beyond it); then compound 3.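

In this assay, the nitrogen on an aromatic ring tolerates a sulfonyl linker in place of a carbonyl: the change gives a 5.0-fold lower number from compound 3 to compound 4 (0.70 log units; beyond the scatter) and a 2.4-fold lower number from compound 2 to compound 4 (0.38 log units; beyond the scatter), the first sulfonyl result in the series. Against the propanoyl group, the same change gives a 1.8-fold lower number from compound 1 to compound 4 (0.26 log units; within the scatter) and so leaves no separation, which means compound 4 cannot be ranked above compound 1. The change replaces linker and ring together, so the contribution of each cannot be read from these compounds, and nothing available accounts for the steps.

Still open, as far as these compounds go, is whether the sulfonyl or the 4-chlorophenyl ring carries the steps, which a (4-chlorophenyl)carbonyl or a (furan-2-yl)sulfonyl group on the same nitrogen would address. Also open, from the compounds shown here alone, is how a small methylsulfonyl group or an unsubstituted phenylsulfonyl group would compare with compound 4.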